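Hydroxy for ethoxycarbonyl: a step from compound 3

The source may hold more compounds than are shown below. What is called first, only, known or untested is meant among the compounds shown, and "the series" means these compounds.

Measured in an assay on kidney for inhibition of tissue alpha-L-fucosidase (Bos taurus), read by spectrophotometry, with a stated time of 10 min; a lower number here means a stronger inhibitor, a higher number a weaker inhibitor:
compound 1 `CC(C)=CCc1cc(-c2oc3cc(O)c(CC=C(C)C)c(O)c3c(=O)c2O)cc(O)c1O` gives 89000 nM
compound 2 `O=C1Nc2cc(Cl)ccc2/C1=C/c1ccc(O)c(O)c1` gives 65000 nM
compound 3 `CCOC(=O)c1ccc(-n2c(/C=C3\OC(=O)c4c3cc(C)[nH]c4=O)ccc2CO)cc1` gives 30400 nM

Compound 3 stands at the lowest number of the three in this assay and is thus the strongest inhibitor of the set; compound 2 lies nearest, at a number beyond the scatter above it, and compound 1 lies furthest. Compounds 1 and 2 both carry hydroxy groups on their outer rings, while compound 3 carries none on its aryl substituent.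

Compound 4 `Cc1cc2c(c(=O)[nH]1)C(=O)O/C2=C\c1ccc(CO)n1-c1ccc(O)cc1` is not yet measured. It differs from compound 3 in one place: hydroxy in place of ethoxycarbonyl on an aromatic carbon. Among the measured compounds shown here, no step between measured compounds matches this change, so the direction rests on the group change alone. Because compound 1 with its hydroxy-bearing ring gives 89000 nM and compound 2 with its hydroxy-bearing ring gives 65000 nM, no gain is expected; a small loss, roughly within the scatter, seems the likeliest outcome, giving an expected step of a 1.3-fold higher number from compound 3 to compound 4 (0.12 log units; within the scatter). Compound 4 is estimated at 40000 nM, with a range from 12000 nM to 130000 nM.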

Compound 4, half-maximal inhibitory concentration: 21700 nM
Beside the measured number, compound 4's estimate is 1.8-fold (0.27 log units) above it, and the stated range covers the measured number.
By their numbers in this assay, from the lowest: compounds 4 and 3 (each within the scatter of the next); then compounds 2 and 1 (each within the scatter of the next).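

In this assay, hydroxy in place of ethoxycarbonyl on this aromatic carbon, para to a large group, gives a 1.4-fold lower number from compound 3 to compound 4 (0.15 log units; within the scatter). Among the compounds shown here, this is the first single-place step, and it shows that the number at this position holds within the scatter when a group of 5 heavy atoms with no hydrogen-bond donor gives way to one of 1 heavy atom with a hydrogen-bond donor, so neither the ethoxycarbonyl nor its size is needed to keep the number at this level. No measurement available here bears on why the two groups read alike.

From the compounds shown here alone, whether an amine, a carboxylic acid or a methoxy group on this carbon would move the number beyond the scatter stays open. For the compounds shown here, with only two groups compared at this position, a single step cannot show how wide the range of tolerated groups is.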